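Methoxy in Place of Nitro on a Shared Core

A few compounds are considered here, and "the series" means these few. Any claim that something is new, unique, unknown or untested is made for them only; others in the source may bear on it.

Compound 1 `O=C(CSc1nnc(COc2ccc3c(c2)CCCC3)o1)Nc1nc2ccccc2s1`: 247000 nM
Compound 2 `O=C(CSc1nnc(COc2ccc3c(c2)CCCC3)o1)Nc1nc2ccc(Cl)cc2s1`: 263000 nM
Compound 3 `O=C(CSc1nnc(COc2ccc3c(c2)CCCC3)o1)Nc1nc2ccc([N+](=O)[O-])cc2s1`: 233000 nM

Three compounds share one core and differ only in the group on one aromatic carbon. In a functional assay on A549 cells (Homo sapiens) for cytotoxicity, read by MTT assay, with a stated time of 24 h (on this read-out higher numbers stand for weaker inhibition and lower numbers for stronger inhibition), compound 1 gives 247000 nM, compound 2 gives 263000 nM, and compound 3 gives 233000 nM. The steps between them are small: a 1.1-fold higher number from compound 1 to compound 2 (0.03 log units; within the scatter), a 1.1-fold lower number from compound 1 to compound 3 (0.03 log units; within the scatter) and a 1.1-fold lower number from compound 2 to compound 3 (0.05 log units; within the scatter). Compound 3 holds the lowest of the three numbers, but its nearest neighbour, compound 1, and its furthest, compound 2, both sit within the scatter of it, so the three are not told apart by this assay.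

Compound 4 `COc1ccc2nc(NC(=O)CSc3nnc(COc4ccc5c(c4)CCCC5)o3)sc2c1` carries the same core; the change from compound 3 is methoxy in place of nitro on an aromatic carbon. All three measured steps bear on this one, since each swaps the group at the same aromatic carbon, and none moved the number beyond the scatter. No step beyond the scatter is therefore expected for compound 4, whose step is estimated as a 1.0-fold higher number from compound 3 to compound 4 (0.01 log units; within the scatter). Compound 4 is expected to give about 240000 nM in this assay, within a range of 120000 nM to 480000 nM.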

Compound 4, half-maximal inhibitory concentration: 39300 nM
Beside the measured number, compound 4's estimate is 6.1-fold (0.79 log units) above it, and the stated range ends above it.
By their numbers in this assay, from the lowest: compound 4; then compounds 3, 1 and 2 (each within the scatter of the next).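

This position on the shared core, an aromatic carbon of a six-membered aromatic ring of carbon only, proves able to move the number in this assay, which hydrogen, chloro and nitro had not shown. Methoxy stands apart from all three groups, with steps of similar, modest size against nitro (a 5.9-fold lower number from compound 3 to compound 4 (0.77 log units; beyond the scatter)), chloro (a 6.7-fold lower number from compound 2 to compound 4 (0.83 log units; beyond the scatter)) and hydrogen (a 6.3-fold lower number from compound 1 to compound 4 (0.80 log units; beyond the scatter)). Compound 4 is thus the only one of the four whose steps to all the others lie beyond the scatter, while the other three remain indistinguishable, and nothing available explains why methoxy alone separates from them.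

The compounds shown leave open whether this step belongs to methoxy alone or would also appear with another group on the same carbon, such as a hydroxyl, an ethoxy or an amine. They also leave open whether methoxy would give a similar step on a different carbon of the same ring, or whether the step would hold on a core carrying any other change.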